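Swapping the Amide Ring: Pyrrolidine to Morpholine

The source may hold more compounds than are shown below. What is called first, only, known or untested is meant among the compounds shown, and "the series" means these compounds.

Compound 1, `CNC(=O)C1CCN(c2ccc(Cl)c(C(F)(F)F)c2)C1`: 1300 nM
Compound 2, `O=C(C1CCN(c2ccc(Cl)c(C(F)(F)F)c2)C1)N1CCCC1`: 410 nM

Within the data shown here, in an assay on cells for inhibition of Palmitoleoyl-protein carboxylesterase NOTUM variant C330S (Homo sapiens), read by fluorescence, with a stated time of 40 min (on this read-out lower numbers stand for stronger inhibition and higher numbers for weaker inhibition), compound 2 holds the lower of the two numbers, and the only measured step, a 3.2-fold lower number from compound 1 to compound 2 (0.50 log units; beyond the scatter), moved the number down by a modest amount. Compound 3, `O=C(C1CCN(c2ccc(Cl)c(C(F)(F)F)c2)C1)N1CCOCC1`, differs from compound 2 by morpholin-4-yl in place of pyrrolidin-1-yl on a carbonyl carbon. Among the measured compounds shown here, no measured step exchanges one ring amine for another, so the earlier step shows only that the amide part can shift the number. For compound 3 in this assay a small step is expected, a 1.5-fold higher number from compound 2 to compound 3 (0.17 log units; within the scatter), possibly not beyond the scatter. The estimate for compound 3 is 600 nM, between 200 nM and 2000 nM.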

Compound 3, half-maximal inhibitory concentration: 9700 nM
Compound 3: the middle estimate sits 16-fold (1.21 log units) below what was measured, outside the stated range (above it).
By their numbers in this assay, from the lowest: compound 2; then compound 1; then compound 3.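

Morpholin-4-yl in place of pyrrolidin-1-yl in this assay gives a 24-fold higher number from compound 2 to compound 3 (1.37 log units; beyond the scatter) on the same carbonyl carbon, so the choice of ring amine here matters far more than the earlier step could show. Morpholin-4-yl in place of methylamino gives a 7.5-fold higher number from compound 1 to compound 3 (0.87 log units; beyond the scatter) in the same assay, so putting a ring on this carbonyl does not by itself lower the number. No measurement shown here explains this change.

On these data alone, what stays open is whether the ring oxygen or the six-membered ring accounts for the change. Piperidin-1-yl, a six-membered ring without that oxygen, would separate the two.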